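A Dihydroxyphenyl Swap in a Level Cytotoxicity Series

The source may hold more compounds than are shown below. What is called first, only, known or untested is meant among the compounds shown, and "the series" means these compounds.

Of the compounds shown here, three sharing one core have so far been measured in a functional assay on A549 cells (Homo sapiens) for cytotoxicity, read by MTT assay, with a stated time of 72 h (a lower number here means a stronger inhibitor, a higher number a weaker inhibitor), and they give nearly the same reading. Compound 3 (`COc1cc2ncnc(Nc3ccc(F)c(Cl)c3)c2cc1NC(=O)N/N=C/c1ccc(O)c(Br)c1`) gives 28600 nM in this test, and it stands level within the scatter with compound 1 (`COc1cc2ncnc(Nc3ccc(F)c(Cl)c3)c2cc1NC(=O)N/N=C/c1ccc(C#N)cc1`) at 32200 nM and with compound 2 (`COc1cc2ncnc(Nc3ccc(F)c(Cl)c3)c2cc1NC(=O)N/N=C/c1cc(OC)c(OC)c(OC)c1`) at 32100 nM on the same scale.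

Compound 4 (`COc1cc2ncnc(Nc3ccc(F)c(Cl)c3)c2cc1NC(=O)N/N=C/c1ccc(O)cc1O`) keeps the core and carries 2,4-dihydroxyphenyl in place of 3-bromo-4-hydroxyphenyl on a carbon with a double bond to nitrogen. Three measured steps change the group at this same place, and they are a 1.0-fold lower number from compound 1 to compound 2 (0.00 log units; within the scatter) and a 1.1-fold lower number from compound 1 to compound 3 (0.05 log units; within the scatter) and a 1.1-fold lower number from compound 2 to compound 3 (0.05 log units; within the scatter) with each one inside the scatter. None of the three measured compounds carries 2,4-dihydroxyphenyl, so these steps offer only indirect guidance for the new group.

On that evidence, no step beyond the scatter is expected in this assay and no direction is favoured. The estimated step is a 1.0-fold higher number from compound 3 to compound 4 (0.01 log units; within the scatter) and it would be too small to separate the two compounds. For compound 4 the expected value is 29000 nM with an estimated range from 15000 nM to 55000 nM in this test.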

Compound 4, half-maximal inhibitory concentration: 31400 nM
Compound 4: middle estimate off by 1.1-fold (0.03 log units), on the low side; the range from low to high includes it.
By their numbers in this assay, from the lowest: compounds 3, 4, 2 and 1 (each within the scatter of the next).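

Placing 2,4-dihydroxyphenyl in place of 3-bromo-4-hydroxyphenyl on a carbon with a double bond to nitrogen gives a 1.1-fold higher number from compound 3 to compound 4 (0.04 log units; within the scatter) in this assay and so removes the bromine, raises the count from 1 hydrogen-bond donor and 1 acceptor to 2 of each, and leaves the reading within the scatter. Set against the other two groups, the new compound gives a 1.0-fold lower number from compound 2 to compound 4 (0.01 log units; within the scatter) and a 1.0-fold lower number from compound 1 to compound 4 (0.01 log units; within the scatter) and stays level with both, so a phenyl carrying two hydroxyl groups now joins the 4-cyanophenyl, 3,4,5-trimethoxyphenyl and 3-bromo-4-hydroxyphenyl groups in a flat set of four at this place. Nothing available accounts for this flat reading.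

Going by these compounds, all four groups at this place are substituted phenyl rings, so it remains open whether a group of another kind, such as a carboxylic acid on the phenyl ring, a dimethylamino group or a saturated piperidine ring, would move the reading beyond the scatter. The four compounds also share the rest of their structure, which leaves open whether this position would stay as flat with any change made elsewhere on the shared core.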